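The source may hold more compounds than are shown below. What is called first, only, known or untested is meant among the compounds shown, and "the series" means these compounds.

Compound 1 `O=C1OCC[C@@H]1NC(=S)SCCOc1ccccc1` is the starting point. In a functional assay on PC-3 cells (Homo sapiens) for antiproliferative activity, read by MTT assay, with a stated time of 72 h (a lower number here means a stronger inhibitor, a higher number a weaker inhibitor), compound 1 gives only a limit, > 64000 nM, and not a number. Compound 2 `O=C1OCC[C@@H]1NC(=S)SCCOc1ccccc1[N+](=O)[O-]` differs from it by nitro in place of hydrogen on an aromatic carbon. In this assay compound 2 gives 24000 nM, which amounts to an at least 2.6-fold lower number from compound 1 to compound 2 (0.42 log units; beyond the scatter). Since the value for compound 1 is a limit (the limit of > 64000 nM in this assay, at which 1 of the 3 values shown sits), the true size of that step is not known beyond this.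

Compound 3 `O=C(COc1ccc(C(=O)/C=C/c2ccccc2)cc1)N[C@H]1CCOC1=O` is built on a different core; how the two cores differ is not broken down here. In this assay compound 3 gives 56800 nM.

Compound 4 `O=C(COc1ccc(C(=O)/C=C/c2cccc([N+](=O)[O-])c2)cc1)N[C@H]1CCOC1=O` differs from compound 3 by nitro in place of hydrogen on an aromatic carbon. This is the same kind of change as that from compound 1 to compound 2, though there the nitro sits ortho to a large group and here it sits meta to a large group.

Resting on the step to compound 2 being an at least 2.6-fold lower number from compound 1 to compound 2 (0.42 log units; beyond the scatter), the step from compound 3 to compound 4 is expected to be a 2.6-fold lower number from compound 3 to compound 4 (0.41 log units; beyond the scatter). For compound 4 in this assay a value of 22000 nM is estimated, most likely between 8000 nM and 60000 nM.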

Compound 4, half-maximal inhibitory concentration: 56300 nM
Compound 4: middle estimate off by 2.6-fold (0.41 log units), on the low side; the range from low to high includes it.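

In this assay the nitro change gives a 1.0-fold lower number from compound 3 to compound 4 (0.00 log units; within the scatter) on this core, so the lower number seen on the core of compound 1 does not reappear here. Set side by side, the two steps read: the same change on two cores in this assay, an at least 2.6-fold lower number (0.42 log units; beyond the scatter) from compound 1 to compound 2 and a 1.0-fold lower number (0.00 log units; within the scatter) from compound 3 to compound 4; the limit leaves it open whether they differ. A lower number on one core therefore cannot simply be assumed on the other, but no size can be put on any difference between the two steps, and the value of compound 1, > 64000 nM, is a limit and not a number.

Each core carries the nitro group in one place only, so the compounds shown leave open whether another place on the ring would change the result on the core of compound 3. They also leave open how a different group on that ring, such as an amine or a carboxylic acid, would behave in this assay on either core.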